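Chain extension at the aromatic substituent of the shared core

The compounds below may be only part of what the source reports. "The series", "measured", "known", "first", "only" and "open" are said of these compounds alone.

Compound 1 `CCOC(=O)C1=C(N)Oc2ccccc2C1C(C#N)C(=O)OCC` gives 66000 nM in a functional assay on Jurkat cells (Homo sapiens) for inhibition; on this read-out lower numbers stand for stronger inhibition of growth and higher numbers for weaker inhibition of growth. Within the data shown here, compound 2 `CCOC(=O)C1=C(N)Oc2ccc(CC)cc2C1C(C#N)C(=O)OCC` gives 13000 nM in this assay, the lowest of the two numbers recorded so far; the only step measured is a 5.1-fold lower number from compound 1 to compound 2 (0.71 log units; beyond the scatter). Compound 3 `CCCc1ccc2c(c1)C(C(C#N)C(=O)OCC)C(C(=O)OCC)=C(N)O2` is not yet measured. Its difference from compound 2 is methyl in place of hydrogen on a saturated chain carbon, two bonds along the chain from an aromatic carbon. Among the measured compounds shown here, the one measured step bears on it only loosely: it shows that adding carbon at this aromatic position lowered the number beyond the scatter, but it says nothing about lengthening a chain already present. The expectation for compound 3 is therefore a smaller step than the earlier one, in the same direction or none beyond the scatter, written as a 1.6-fold lower number from compound 2 to compound 3 (0.21 log units; within the scatter). Compound 3 is estimated at 8000 nM in this assay, with a range from 3000 nM to 20000 nM.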

Compound 3, concentration for 50% growth inhibition: 5200 nM
For compound 3 the middle estimate is 1.5-fold (0.19 log units) above the measured one; the range from low to high includes it.
By their numbers in this assay, from the lowest: compound 3; then compound 2; then compound 1.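

In this assay, methyl in place of hydrogen on a saturated chain carbon, two bonds along the chain from an aromatic carbon, gives a 2.5-fold lower number from compound 2 to compound 3 (0.40 log units; beyond the scatter) and so shows that lengthening a chain already present at this position still moves the number beyond the scatter, which the ethyl step alone could not show. The whole change is a 13-fold lower number from compound 1 to compound 3 (1.10 log units; beyond the scatter), and across hydrogen, ethyl and propyl the number falls at each step, with none of the three compounds going against this. No measurement bears on the reason for this fall.

As far as these compounds go, whether the fall continues with a longer chain such as butyl, or holds for a branched chain such as isopropyl, remains open. Also open, from the compounds shown here alone, is how an amine or a carboxylic acid in place of the propyl would compare.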